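The compounds below may be only part of what the source reports. "The series", "measured", "known", "first", "only" and "open" are said of these compounds alone.

Compound 2 `Cc1nc(N(C)C(=O)NC(=O)c2c(F)cccc2F)sc1C(=O)N/N=C/c1cccc(C(F)(F)F)c1` stands highest of the two numbers in a functional assay on BCG823 cells (Homo sapiens) for inhibition, read by MTT assay, with a stated time of 72 h (a lower number here means a stronger inhibitor, a higher number a weaker inhibitor), where compound 2 gives 32.7 ug/mL. For the measured compounds named here, compound 1 `CN(C(=O)NC(=O)c1c(F)cccc1F)c1nc(C(F)(F)F)c(C(=O)N/N=C/c2cccc(C(F)(F)F)c2)s1` gives 25.9 ug/mL; the step of a 1.3-fold higher number from compound 1 to compound 2 (0.10 log units; within the scatter) is the only measured one-place change in the set. Compound 3 `CNc1nc(C)c(C(=O)N/N=C/c2ccc(C(F)(F)F)cc2)s1` reaches only a limit in this assay, > 100 ug/mL. One of the three values thus sits at the limit of > 100 ug/mL in this assay, at which 1 of the 3 values shown sits.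

Compound 4 `Cc1nc(N(C)C(=O)NC(=O)c2c(F)cccc2F)sc1C(=O)N/N=C/c1cc(C(F)(F)F)cc(C(F)(F)F)c1` differs from compound 2 by trifluoromethyl in place of hydrogen on an aromatic carbon. Going by the values given here, no measured step touches this ring, and the one measured step, on the core, stayed within the scatter, so no step beyond the scatter is expected in this assay: the expected step is a 1.1-fold lower number from compound 2 to compound 4 (0.04 log units; within the scatter). Compound 4 is estimated at 30 ug/mL, with a range from 15 ug/mL to 70 ug/mL.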

Compound 4, half-maximal inhibitory concentration: 14.1 ug/mL
For compound 4 the middle estimate is 2.1-fold (0.33 log units) above the measured one; measured number below the stated range.
By their numbers in this assay, from the lowest: compounds 4, 1 and 2 (each within the scatter of the next, the first and the last beyond it). At a limit, above all of these: compound 3.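

In this assay, for the compounds shown here, trifluoromethyl in place of hydrogen on the six-membered aromatic ring gives the first step beyond the scatter, a modest one: a 2.3-fold lower number from compound 2 to compound 4 (0.37 log units; beyond the scatter). Going by these compounds alone, this place, meta to a large group and meta to a trifluoromethyl group, therefore changes the read-out, whereas the one earlier step, on the core, stayed within the scatter. Nothing measured here gives a cause for this step.

Whether the change depends on trifluoromethyl itself stays open, since a methoxy group or an amine at the same place is not among the compounds shown. As far as these compounds go, how far this step carries over to other cores also stays open.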